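This account rests on a few compounds, and the source may have more. Where it says the series, first, only, none or still open, it means among the compounds named here.

The shared core of these compounds, a sugar-bearing bicyclic system, carries two variable groups. In a functional assay on K562 cells (Homo sapiens), read by MTT assay, with a stated time of 72 h (a higher number here means a weaker inhibitor, a lower number a stronger inhibitor), compound 1 `C#Cc1cn([C@@H]2O[C@H](CO)[C@@H](O)[C@H]2O)c2ncnc(N(C)C)c12` gives 260 nM. Compound 2 `C#Cc1cn([C@@H]2O[C@H](CO)[C@@H](O)[C@H]2O)c2ncnc(NC)c12` gives 1380 nM in this assay, and the change between them is a 5.3-fold higher number from compound 1 to compound 2 (0.72 log units; beyond the scatter). Compound 3 `CNc1ncnc2c1c(I)cn2[C@@H]1O[C@H](CO)[C@@H](O)[C@H]1O` gives > 20000 nM in this assay, which is a limit of the assay and not a number. The further change is an at least 14-fold higher number from compound 2 to compound 3 (1.16 log units; beyond the scatter). Compound 2 therefore holds the highest of the two numbers shown, with compound 1 the nearest, beyond the scatter below it.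

Compound 4 `C#Cc1cn([C@@H]2O[C@H](CO)[C@@H](O)[C@H]2O)c2ncnc(SC)c12` differs from compound 2 by methylsulfanyl in place of methylamino on an aromatic carbon. Among the compounds with values here, of the measured steps, only the one from compound 1 to compound 2 concerns the same position, and it was modest; the step from compound 2 to compound 3 concerns a different aromatic carbon and does not bear directly on this change. Compound 1, which also lacks a hydrogen-bond donor at this position, shows that a donor there is not required for a low number. A modest step in this assay is therefore expected, with the direction uncertain, as a 2.3-fold lower number from compound 2 to compound 4 (0.36 log units; beyond the scatter). Compound 4 is estimated at 600 nM, within a range from 150 nM to 2500 nM.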

Compound 4, half-maximal inhibitory concentration: 70 nM
The estimate for compound 4 lay 8.6-fold (0.93 log units) above the measured number; measured number outside the range, below it.
By their numbers in this assay, from the lowest: compound 4; then compound 1; then compound 2. At a limit, above all of these: compound 3.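

The move from a nitrogen-linked to a sulfur-linked group at this aromatic carbon gives the largest measured change in number among the ethynyl compounds in this assay, with a 20-fold lower number from compound 2 to compound 4 (1.29 log units; beyond the scatter). Within the data shown here, until now, this position had been seen only with methylamino and dimethylamino, and the lowest number belonged to compound 1, but methylsulfanyl goes further still, with a 3.7-fold lower number from compound 1 to compound 4 (0.57 log units; beyond the scatter). Compound 1 and compound 4 both lack a hydrogen-bond donor here and still stand apart beyond the scatter, so the absence of a donor does not by itself set the number at this position.

On these data alone, whether the low number is kept with a longer chain on the sulfur, such as ethylsulfanyl, or with a methoxy group at the same carbon remains open, as does whether iodo in place of ethynyl would cost as much in a compound carrying methylsulfanyl as it does in one carrying methylamino. The information available includes no measurement that bears on the reason for the drop from methylamino to methylsulfanyl.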